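The source may hold more compounds than are shown below. What is called first, only, known or untested is meant among the compounds shown, and "the series" means these compounds.

Within the data shown here, in an ADME assay on the whole organism (plasma, strain BALB/c) for pharmacokinetics, with Mus musculus as the target, at a dose of 5 mg/kg by the oral route (a higher number here means more compound in the circulation at the dose given, a lower number less compound in the circulation), three compounds have values so far: compound 1 (`CCCS(=O)(=O)c1cccc(C#Cc2cc(Cl)ccc2OCC(=O)O)c1`) gives 5760 ng.h/mL, compound 2 (`CN(C)S(=O)(=O)c1ccc(F)c(C#Cc2cc(Cl)ccc2OCC(=O)O)c1`) gives 4880 ng.h/mL and compound 3 (`CC(C)S(=O)(=O)c1ccc(Cl)c(C#Cc2cc(Cl)ccc2OCC(=O)O)c1`) gives 4890 ng.h/mL. Compound 2 stands level with both of the others, since all three values lie within the usual scatter of each other and no order can be read from them.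

The next compound is compound 4 (`CCCS(=O)(=O)c1ccc(F)c(C#Cc2cc(Cl)ccc2OCC(=O)O)c1`), which differs from compound 2 as follows: propyl in place of dimethylamino on a sulfonyl sulfur. That is propyl in place of dimethylamino on a sulfonyl sulfur. Among the measured compounds shown here, no pair of measured compounds differing in one place is available, so this change has no direct precedent. In this assay, no step beyond the scatter is expected. For the measured compounds named here, the only support is that compound 1, which also has propyl on a sulfonyl sulfur, gives 5760 ng.h/mL, within the scatter of compound 2 at 4880 ng.h/mL.

The expected change is a 1.1-fold higher number from compound 2 to compound 4 (0.03 log units; within the scatter). For compound 4, the estimated value is 5200 ng.h/mL, with an expected range of 2600 ng.h/mL to 10000 ng.h/mL.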

Compound 4, area under the concentration-time curve: 6140 ng.h/mL
Compound 4: middle estimate off by 1.2-fold (0.07 log units), on the low side; the measured number falls inside the stated range.
By their numbers in this assay, from the lowest: compounds 2, 3, 1 and 4 (each within the scatter of the next).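

In this assay the series now has its first single-change comparisons. Propyl in place of dimethylamino on a sulfonyl sulfur gives a 1.3-fold higher number from compound 2 to compound 4 (0.10 log units; within the scatter), and fluoro in place of hydrogen on an aromatic carbon gives a 1.1-fold higher number from compound 1 to compound 4 (0.03 log units; within the scatter). Neither change separates the paired compounds, so dimethylsulfamoyl and propylsulfonyl stand level in this pair, as do fluoro and hydrogen in the other; no measurement is available that bears on a cause for either result.

Going by these compounds, whether a different kind of group on the sulfonyl sulfur, such as a morpholine amide or a longer chain, would give a step beyond the scatter remains open. On these data alone, it is also open whether methoxy in place of fluoro on that aromatic carbon would do so.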